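This account rests on a few compounds, and the source may have more. Where it says the series, first, only, none or still open, it means among the compounds named here.

Compounds measured so far:
compound 1 `COc1ccccc1/C=C/C(=O)c1ccc(OCCn2cc(CN3C(=O)/C=C/C(C)(C)C/C=C(\C)CC/C=C/3C)nn2)cc1O` — 1.17 ug/mL
compound 2 `C/C1=C\CC(C)(C)/C=C/C(=O)N(Cc2cn(CCOc3ccc(C(=O)/C=C/c4ccc(C)cc4)c(O)c3)nn2)/C(C)=C/CC1` — 1.21 ug/mL

Among the measured compounds shown here, in a functional assay on MCF7 cells (Homo sapiens) for antiproliferative activity (on this read-out higher numbers stand for weaker inhibition and lower numbers for stronger inhibition), compound 2 gives 1.21 ug/mL, and the only other number, from compound 1, lies within the scatter of it, as a 1.0-fold higher number from compound 1 to compound 2 (0.01 log units; within the scatter) shows. Compound 3 `C/C1=C\CC(C)(C)/C=C/C(=O)N(Cc2cn(CCOc3ccc(C(=O)/C=C/c4ccc(C(C)C)cc4)c(O)c3)nn2)/C(C)=C/CC1` differs from compound 2 by isopropyl in place of methyl on an aromatic carbon. For the measured compounds named here, the single measured step, which exchanged the whole aryl group, moved nothing beyond the scatter, so a change at the same place is expected to move little. The step from compound 2 to compound 3 is estimated as a 1.1-fold higher number from compound 2 to compound 3 (0.03 log units; within the scatter). Compound 3 is expected to give about 1.3 ug/mL, in a range from 0.6 ug/mL to 2.8 ug/mL.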

Compound 3, half-maximal inhibitory concentration: 0.93 ug/mL
For compound 3 the middle estimate is 1.4-fold (0.15 log units) above the measured one; the measured number falls inside the stated range.
By their numbers in this assay, from the lowest: compounds 3, 1 and 2 (each within the scatter of the next).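

In this assay, isopropyl in place of methyl on the aromatic carbon gives a 1.3-fold lower number from compound 2 to compound 3 (0.11 log units; within the scatter), so a larger alkyl group at this place leaves the number within the scatter. Exchanging the whole aryl group gives a 1.3-fold lower number from compound 1 to compound 3 (0.10 log units; within the scatter), so 2-methoxyphenyl, 4-methylphenyl and 4-isopropylphenyl all read alike here. No available measurement offers a reason for this flat result. Still open, as far as these compounds go, is whether an amine or a carboxylic acid on the same aromatic carbon would also stay within the scatter.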